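Swapping an acetyl for a pyrimidinyl on a distal ring

The compounds below may be only part of what the source reports. "The series", "measured", "known", "first", "only" and "open" are said of these compounds alone.

Of the compounds shown here, three sharing one core have been measured in an assay on isolated protein for binding affinity to 5-hydroxytryptamine receptor 1D (Homo sapiens); a higher number here means a weaker inhibitor, a lower number a stronger inhibitor. Compound 1 `COc1cc2c(cc1N1C[C@@H](C)N(C)[C@@H](C)C1)N(C(=O)Nc1cccc(Cl)c1Cl)CC2` gives 79.4 nM. Compound 2 `COc1cc2c(cc1N1C[C@@H](C)N[C@@H](C)C1)N(C(=O)c1ccc(-c3ccc(C(C)=O)cc3C)cc1)CC2` gives 398 nM, and compound 3 `COc1cc2c(cc1N1C[C@@H](C)N[C@@H](C)C1)N(C(=O)c1ccc(-c3cc(C)ncc3C)cc1)CC2` gives 501 nM. Among these three numbers compound 2 holds the second highest; compound 3 sits nearest to it, while compound 1 sits furthest, with a number that is lower by a margin beyond the scatter. The step of a 1.3-fold higher number from compound 2 to compound 3 (0.10 log units; within the scatter) exchanged the outer ring of the biaryl unit for a pyridine and left the number within the scatter.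

Compound 4 `COc1cc2c(cc1N1C[C@@H](C)N[C@@H](C)C1)N(C(=O)c1ccc(-c3ccc(-c4ncccn4)cc3C)cc1)CC2` has not been measured. It differs from compound 2 by pyrimidin-2-yl in place of acetyl on an aromatic carbon. Among the compounds with values here, the only measured step that touches the same outer ring is that from compound 2 to compound 3, which stayed within the scatter, so no step beyond the scatter is expected here either. Compound 4 is therefore expected to come in at about 400 nM, within a range of 150 nM to 1100 nM, which corresponds to an expected step of a 1.0-fold higher number from compound 2 to compound 4 (0.00 log units; within the scatter).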

Compound 4, inhibition constant: 251 nM
Compound 4: middle estimate off by 1.6-fold (0.20 log units), on the high side; low and high end bracket the measured number.
By their numbers in this assay, from the lowest: compound 1; then compounds 4, 2 and 3 (each within the scatter of the next).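

Exchanging the acetyl for the larger, ring-bearing pyrimidin-2-yl on the outer ring gives a 1.6-fold lower number from compound 2 to compound 4 (0.20 log units; within the scatter) in this assay, so this site, para to a large group and meta to a methyl group, accepts an added aromatic ring with no change beyond the scatter. Unlike the earlier step, which replaced the outer ring itself, this one changes only the group on that ring and so gives the first direct reading of this position. Nothing available here accounts for this result.

With only acetyl and pyrimidin-2-yl at this position, the compounds shown cannot indicate how far such tolerance extends. A carboxylic acid, a primary amine or a longer chain such as n-butyl at the same carbon remains an open test.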